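The source may hold more compounds than are shown below. What is called first, only, known or untested is meant among the compounds shown, and "the series" means these compounds.

Measured compounds:
Compound 1 `Cc1cc(-c2cc(Cl)cc(Cl)c2)c(S(C)(=O)=O)cc1C(=O)N=C(N)N` in a functional assay for inhibition of sodium/hydrogen exchanger (Oryctolagus cuniculus); a lower number here means a stronger inhibitor, a higher number a weaker inhibitor: compound 1 gives 130 nM
Compound 2 `Cc1cc(-c2ccccc2)c(S(C)(=O)=O)cc1C(=O)N=C(N)N`: compound 2 gives 19 nM
Compound 3 `CCSc1cc(C)c(C(=O)N=C(N)N)cc1S(C)(=O)=O`: compound 3 gives 5.9 nM

Compound 3 holds the lowest number of the three, with compound 2 the nearest (a 3.2-fold lower number from compound 2 to compound 3 (0.51 log units; beyond the scatter)) and compound 1 the furthest (a 22-fold lower number from compound 1 to compound 3 (1.34 log units; beyond the scatter)). Compound 4 `Cc1cc(Sc2cccc(Cl)c2)c(S(C)(=O)=O)cc1C(=O)N=C(N)N` differs from compound 3 in one place: 3-chlorophenyl in place of ethyl on a sulfur. For the measured compounds named here, two measured steps bear on this. Replacing an aromatic ring on the core by ethylsulfanyl brought the number down, as seen in a 3.2-fold lower number from compound 2 to compound 3 (0.51 log units; beyond the scatter) and a 22-fold lower number from compound 1 to compound 3 (1.34 log units; beyond the scatter); between the two rings, phenyl did better than 3,5-dichlorophenyl (a 6.8-fold lower number from compound 1 to compound 2 (0.84 log units; beyond the scatter)). Going by the values given here, compound 4 reintroduces a chlorine-bearing ring, though now on the sulfur rather than on the aromatic carbon, and no measured pair tests a ring on sulfur. A modest rise is therefore expected, of about a 4.2-fold higher number from compound 3 to compound 4 (0.63 log units; beyond the scatter), smaller than the whole gap from compound 3 back to compound 1. Compound 4 is estimated at 25 nM, with a range from 8 nM to 80 nM.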

Compound 4, half-maximal inhibitory concentration: 37 nM
For compound 4 the middle estimate is 1.5-fold (0.17 log units) below the measured one; low and high end bracket the measured number.
By their numbers in this assay, from the lowest: compound 3; then compounds 2 and 4 (each within the scatter of the next); then compound 1.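

In this assay, the step at the sulfur itself, with 3-chlorophenyl in place of ethyl, gives a 6.3-fold higher number from compound 3 to compound 4 (0.80 log units; beyond the scatter), so on this sulfur the small ethyl group outperforms this aromatic ring. Carrying a ring on the core through sulfur gives no clear separation from the plain phenyl, with a 1.9-fold higher number from compound 2 to compound 4 (0.29 log units; within the scatter) as (3-chlorophenyl)sulfanyl replaces phenyl, yet the same group improves on 3,5-dichlorophenyl, with a 3.5-fold lower number from compound 1 to compound 4 (0.55 log units; beyond the scatter) on that aromatic carbon. Nothing available accounts for the size of these steps. As far as these compounds go, whether the ethyl result extends to a longer chain such as propyl on the sulfur remains open. So does how much of the step from ethyl belongs to the ring and how much to its chlorine, which a plain phenyl on the sulfur would separate.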